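The source may report more compounds than this note shows. Statements on the series, on what has been measured and on what is new or still open speak of the compounds shown alone.

Values in an ADME assay on HepG2 cells (Homo sapiens) for cytotoxicity, with a stated time of 72 h; a higher number here means that more compound is needed for the effect, a lower number that less compound is needed:

Compound 1 `CCc1ccc(NC(=O)Nc2cc(C)nc3ccccc23)cc1`: 17000 nM
Compound 2 `Cc1cc(NC(=O)Nc2cccc(C(N)=O)c2)c2ccccc2n1`: > 25000 nM

Only compound 1 has a true number, so the series has one fixed point so far. Compound 2 reads > 25000 nM, which is a limit of the assay and not a number. Going by the values given here, its place on the scale is therefore known only as that limit, and no measured step exists between any two compounds to size a change.

The next compound is compound 3 `Cc1cc(NC(=O)Nc2cccc(F)c2)c2ccccc2n1`, which has fluoro in place of carbamoyl on an aromatic carbon, meta to a large group (fluoro in place of carbamoyl on an aromatic carbon). Among the compounds with values here, with no step to draw on, the expectation in this assay is loose. Within the data shown here, the only anchor is compound 1 at 17000 nM, so a modest move towards a lower number is expected. A second reading at the limit remains quite possible. The expected change is an at least 1.3-fold lower number from compound 2 to compound 3 (0.11 log units; that floor lies within the scatter). For compound 3 the estimated value is 19000 nM, with an expected range from 9000 nM to 35000 nM.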

Compound 3, half-maximal effective concentration: > 25000 nM
Compound 3 was reported as a limit; the forecaster's own chance of this, stated with the estimate: 40%; middle value at least 1.3-fold (0.11 log units) from the limit.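

No step can be read from compound 2 to compound 3 in this assay, because each of the two is reported only as a limit and not as a number: the limit of > 25000 nM in this assay, at which 2 of the 3 values shown sit.

Left open is whether fluoro in place of carbamoyl on an aromatic carbon changes the half-maximal effective concentration in this assay at all, and in which direction.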